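Bromo on the Pendant Phenyl of a Bis-Chalcone Phenol

A few compounds are considered here, and "the series" means these few. Any claim that something is new, unique, unknown or untested is made for them only; others in the source may bear on it.

Compound 1 `Cc1cc(O)c(C(=O)/C=C/c2ccccc2)c(-c2ccccc2)c1C(=O)/C=C/c1ccccc1` carries a phenol core bearing two cinnamoyl arms and a plain phenyl ring. In a functional assay on HeLa cells (Homo sapiens) for cytotoxicity, read by MTT assay, with a stated time of 24 h (a lower number here means a stronger inhibitor, a higher number a weaker inhibitor), compound 1 is reported as "not active" (no number reported), so no number places it on the scale. Two relatives put a halogen on each cinnamoyl arm instead: compound 2 `Cc1cc(O)c(C(=O)/C=C/c2ccc(F)cc2)c(-c2ccccc2)c1C(=O)/C=C/c1ccc(F)cc1` gives 30000 nM in this assay, and compound 3 `Cc1cc(O)c(C(=O)/C=C/c2ccc(Cl)cc2)c(-c2ccccc2)c1C(=O)/C=C/c1ccc(Cl)cc1` gives 30000 nM. These two values sit within the usual scatter of each other, so they read as equally weak inhibitors.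

Compound 4 `Cc1cc(O)c(C(=O)/C=C/c2ccccc2)c(-c2ccc(Br)cc2)c1C(=O)/C=C/c1ccccc1` changes compound 1 at a different spot: bromo in place of hydrogen on an aromatic carbon. For the measured compounds named here, no measured pair differs by exactly this change, so the size of the step in this assay is not known from the data. Given that compound 1 is "not active" (no number reported) and the halogenated relatives compound 2 and compound 3 reach only 30000 nM, a small move toward weak, measurable activity seems the most that should be expected, with a real chance of no number at all. Compound 4 is therefore expected to give about 30000 nM in this assay, plausibly between 8000 nM and 100000 nM.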

Compound 4, half-maximal inhibitory concentration: 30000 nM
Compound 4: the middle estimate sits on the measured number at the digits printed, within the range that was stated.
By their numbers in this assay, from the lowest: compounds 2, 3 and 4 (each within the scatter of the next).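

Compound 1 has no number in this assay and so the step to compound 4 at 30000 nM cannot be read. The compounds shown leave open what the change from phenyl to 4-bromophenyl does on its own. No other measurement shown bears on this result.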